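The compounds below may be only part of what the source reports. "The series", "measured", "known", "first", "only" and "open" are said of these compounds alone.

In a functional assay on DU-145 cells (Homo sapiens) for inhibition, read by trypan blue exclusion, with a stated time of 72 h (a higher number here means a weaker inhibitor, a lower number a stronger inhibitor), compound 1 `Cc1ccc(S(=O)(=O)c2cc3cnc(Nc4ccc5[nH]ccc5c4)nc3n(C)c2=O)cc1` gives 750 nM, compound 2 `Cc1ccc(S(=O)(=O)c2cc3cnc(Nc4cccc5cccnc45)nc3n(C)c2=O)cc1` gives 10000 nM and compound 3 `Cc1ccc(S(=O)(=O)c2cc3cnc(Nc4ccc5ncccc5c4)nc3n(C)c2=O)cc1` gives 10000 nM. Compound 3 is therefore level with compound 2, and together they have the highest of the three numbers. Compound 4 `Cc1ccc(S(=O)(=O)c2cc3cnc(Nc4cccc5[nH]ccc45)nc3n(C)c2=O)cc1` carries 1H-indol-4-yl in place of quinolin-6-yl on a nitrogen on an aromatic ring. The nearest evidence is a 13-fold higher number from compound 1 to compound 3 (1.12 log units; beyond the scatter), a large step from 1H-indol-5-yl to quinolin-6-yl, matched by a 13-fold higher number from compound 1 to compound 2 (1.12 log units; beyond the scatter) for quinolin-8-yl. Moving the quinoline attachment made no difference: no change at the digits printed from compound 2 to compound 3 (within the scatter). Within the data shown here, no measured compound has 1H-indol-4-yl, so a smaller reversal of that step is expected in this assay. The expected change is a 4.0-fold lower number from compound 3 to compound 4 (0.60 log units; beyond the scatter). For compound 4, the estimated value is 2500 nM, within a range of 600 nM to 10000 nM.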

Compound 4, half-maximal inhibitory concentration: 10000 nM
For compound 4 the middle estimate is 4.0-fold (0.60 log units) below the measured one; low and high end bracket the measured number.
By their numbers in this assay, from the lowest: compound 1; then compounds 2, 3 and 4 (each within the scatter of the next).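

In this assay, an indole group alone is not enough for the lower number: the change of attachment from 1H-indol-5-yl to 1H-indol-4-yl gives a 13-fold higher number from compound 1 to compound 4 (1.12 log units; beyond the scatter), so the attachment point on the indole matters here. The quinolines offer no such contrast, and 1H-indol-4-yl matches them, with no change at the digits printed from compound 3 to compound 4 (within the scatter) and no change at the digits printed from compound 2 to compound 4 (within the scatter). Among these compounds, only the 1H-indol-5-yl group of compound 1 stands apart.

No measurement here explains the gap between the two indole groups. As far as these compounds go, whether 1H-indol-6-yl or a phenyl ring carrying an amine would reach the number of compound 1 remains open.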